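From Ethynyl to Fluoro on the Aromatic Ring

The compounds below may be only part of what the source reports. "The series", "measured", "known", "first", "only" and "open" are said of these compounds alone.

Of the compounds shown here, three sharing one core have been measured in an ADME assay on microsomes from liver (Homo sapiens) for metabolic stability, read by LC-MS, using NADPH, with a stated time of 10 min, tested at 0.1 uM; on this read-out higher numbers stand for fast clearance and lower numbers for slow clearance. Compound 1 `Cc1cccc(N2C(=O)CSC2c2cccc(C(=O)NCCCCc3ccccc3)c2)c1` gives 2550 mL.min-1.g-1, and compound 2 `O=C(NCCCCc1ccccc1)c1cccc(C2SCC(=O)N2c2cccc(-c3c[nH]nn3)c2)c1` gives 261 mL.min-1.g-1. Compound 3 `C#Cc1cccc(N2C(=O)CSC2c2cccc(C(=O)NCCCCc3ccccc3)c2)c1` lies between them at 751 mL.min-1.g-1, the second highest of the three numbers. The next compound, compound 4 `O=C(NCCCCc1ccccc1)c1cccc(C2SCC(=O)N2c2cccc(F)c2)c1`, has fluoro in place of ethynyl on an aromatic carbon. Two measured steps at this same place end on the ethynyl group: a 3.4-fold lower number from compound 1 to compound 3 (0.53 log units; beyond the scatter), and a 2.9-fold higher number from compound 2 to compound 3 (0.46 log units; beyond the scatter). Both are modest but beyond the scatter, so a change at this place can move the number. Neither step involves fluoro, however, so they give no direct guide to its effect, and the safest expectation is that compound 4 stays close to compound 3. The expected step is a 1.2-fold higher number from compound 3 to compound 4 (0.08 log units; within the scatter), which would not go beyond the scatter. For compound 4 the estimated value is 900 mL.min-1.g-1, with an expected range from 300 mL.min-1.g-1 to 2300 mL.min-1.g-1.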

Compound 4, intrinsic clearance in microsomes in the Homo sapiens assay: 1840 mL.min-1.g-1
Estimate against measurement, compound 4: 2.0-fold (0.31 log units) below; low and high end bracket the measured number.
By their numbers in the Homo sapiens assay, from the lowest: compound 2; then compound 3; then compounds 4 and 1 (each within the scatter of the next).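

In the Homo sapiens assay compound 4 gives 1840 mL.min-1.g-1, and the change from ethynyl to fluoro on its own moves the number at this position on the aromatic ring (a 2.5-fold higher number from compound 3 to compound 4 (0.39 log units; beyond the scatter)). Fluoro and methyl cannot be told apart here (a 1.4-fold lower number from compound 1 to compound 4 (0.14 log units; within the scatter)), whereas the 1H-1,2,3-triazol-4-yl group keeps the lowest number of the four, clearly separate from fluoro (a 7.0-fold higher number from compound 2 to compound 4 (0.85 log units; beyond the scatter)). In a physicochemical assay for solubility, read by turbidimetry, measured as kinetic solubility, at pH 7.4 (a lower number here means a less soluble compound, a higher number a more soluble compound), compound 3 gives 10000 nM and compound 4 gives 10000 nM, and the same swap of ethynyl for fluoro shows no movement (no change at the digits printed from compound 3 to compound 4 (within the scatter)).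

Nothing measured here bears on why the clearance number differs between these groups. On these data alone, whether an amine or a carboxylic acid on this aromatic carbon would fall near the triazole at the low end or near fluoro and methyl at the high end remains open.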